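This account rests on a few compounds, and the source may have more. Where it says the series, first, only, none or still open, it means among the compounds named here.

Compound 1 `CC1=C(/C=C/C(=O)/C=C/c2ccc(Cl)cc2)C(C)(C)CCC1` is read in a functional assay on HeLa cells (Homo sapiens) for cytotoxicity, read by sulforhodamine B assay, with a stated time of 48 h (on this read-out higher numbers stand for weaker inhibition and lower numbers for stronger inhibition), where compound 1 gives 33200 nM, the higher of the two numbers in hand. Compound 2 `CC1=C(/C=C/C(=O)/C=C/c2ccc(C#N)cc2)C(C)(C)CCC1` gives 22200 nM in this assay, and the step of a 1.5-fold lower number from compound 1 to compound 2 (0.17 log units; within the scatter) is the only one measured on the aromatic substituent. Compound 3 `CC1=C(/C=C/C(=O)/C=C/c2ccc(C)cc2)C(C)(C)CCC1` differs from compound 1 by methyl in place of chloro on an aromatic carbon. One within-scatter step at this position gives little ground for a directional expectation, so no shift beyond the scatter is expected; the step of a 1.1-fold lower number from compound 1 to compound 3 (0.04 log units; within the scatter) is the estimate. Compound 3 is therefore expected near 30000 nM, within 12000 nM to 75000 nM.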

Compound 3, half-maximal inhibitory concentration: 20400 nM
Compound 3: the middle estimate sits 1.5-fold (0.17 log units) above what was measured; measured number inside the range.
By their numbers in this assay, from the lowest: compounds 3, 2 and 1 (each within the scatter of the next).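

In this assay, methyl gives no separation from chloro (a 1.6-fold lower number from compound 1 to compound 3 (0.21 log units; within the scatter)) or from cyano (a 1.1-fold lower number from compound 2 to compound 3 (0.04 log units; within the scatter)). With three groups now read on the aromatic carbon, both new steps stay within the scatter, and the three compounds show no order at this position. No supporting measurement bears on this result.

As far as these compounds go, whether an amine, a carboxylic acid or a longer chain in this place would move the number beyond the scatter remains open. Also open, from the compounds shown here alone, is whether a change elsewhere on the shared core would do so.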